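The source may report more compounds than this note shows. Statements on the series, on what has been measured and on what is new or still open speak of the compounds shown alone.

Working notes on the series.

Compound 1 `COc1ccccc1C[C@H]1C(=O)OC[C@@H]1Cc1ccccc1` gives 79000 nM in a functional assay on HL-60 cells (Homo sapiens) for cytotoxicity, read by WST assay, with a stated time of 48 h; on this read-out higher numbers stand for an effect only at larger amounts of compound and lower numbers for an effect already at smaller amounts. Compound 2 `Cc1ccccc1C[C@H]1C(=O)OC[C@@H]1Cc1ccccc1` gives 57000 nM in this assay. Among the compounds with values here, the only structural change between them is methyl in place of methoxy on an aromatic carbon and the step it made is a 1.4-fold lower number from compound 1 to compound 2 (0.14 log units; within the scatter).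

Compound 3 `COc1cccc(C[C@H]2COC[C@@H]2Cc2ccc(Cl)c(Cl)c2)c1` carries a different core; how its core differs from that of compound 1 is not broken down here. In this assay compound 3 gives 73000 nM, a value that lies within the scatter of both compound 1 and compound 2.

Compound 4 `Cc1cccc(C[C@H]2COC[C@@H]2Cc2ccc(Cl)c(Cl)c2)c1` is not yet measured. It differs from compound 3 by methyl in place of methoxy on an aromatic carbon. Within the data shown here, this is the same kind of change as the one from compound 1 to compound 2, but the place is not identical: in compound 1 the methoxy sits ortho to a large group, in compound 3 it sits meta to a large group, and the cores differ.

Given that the only measured example of this change, a 1.4-fold lower number from compound 1 to compound 2 (0.14 log units; within the scatter), stayed within the scatter, a step of a 1.3-fold lower number from compound 3 to compound 4 (0.12 log units; within the scatter) is expected from compound 3 to compound 4. Compound 4 is therefore estimated to give about 55000 nM in this assay, with a plausible range from 25000 nM to 120000 nM.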

Compound 4, half-maximal effective concentration: 28000 nM
Estimate against measurement, compound 4: 2.0-fold (0.29 log units) above, and the stated range covers the measured number.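

In this assay, methyl in place of methoxy on an aromatic carbon, meta to a large group, gives a 2.6-fold lower number from compound 3 to compound 4 (0.42 log units; beyond the scatter). Set beside the earlier case on the core of compound 1, the two steps cannot be told apart in size: the same change on two cores in this assay, a 1.4-fold lower number (0.14 log units; within the scatter) from compound 1 to compound 2 and a 2.6-fold lower number (0.42 log units; beyond the scatter) from compound 3 to compound 4, 1.9-fold (0.27 log units) apart, within the scatter of two such steps. Within the data shown here, this gives no sign that the step depends on the core, but only one of the two steps lies beyond the scatter, the core and the place of the group vary together across the two pairs, and two pairs set no rule for any further core.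

The compounds shown leave open how other groups on this aromatic carbon would read, such as a hydroxyl, an amine, a carboxylic acid or a longer chain in place of the methoxy. They also leave open whether the step seen here would hold with the methyl and methoxy pair on other aromatic positions of either core.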